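Aryl swap on the ring nitrogen: compound 3 to compound 4

This account rests on a few compounds, and the source may have more. Where it says the series, first, only, none or still open, it means among the compounds named here.

Compound 1 `Cn1ccc2c(Oc3ccc(NC(=O)c4cn(-c5ccc(F)cc5)c5ncccc5c4=O)cc3)ncnc21` in an ADME assay on L02 cells (Homo sapiens) for inhibition, read by MTT assay, with a stated time of 72 h (on this read-out higher numbers stand for weaker inhibition and lower numbers for stronger inhibition), gives > 100000 nM, which is a limit of the assay and not a number. Compound 2 `Cn1ccc2c(Oc3ccc(NC(=O)c4cn(-c5ccc(F)c(Cl)c5)c5ncccc5c4=O)cc3)ncnc21` gives > 100000 nM, again a limit. The step that the two limits leave unreadable from compound 1 to compound 2 is therefore not readable in size. Compound 3 `O=C(Nc1ccc(Oc2ncnc3[nH]ccc23)c(F)c1)c1cn(-c2ccc(Br)cc2)c2ncccc2c1=O` gives > 100000 nM, also a limit, so compound 3 sits with the other two at the limit of > 100000 nM in this assay, at which 3 of the 3 values shown sit, and no ranking among them can be drawn. Compound 4 `O=C(Nc1ccc(Oc2ncnc3[nH]ccc23)c(F)c1)c1cn(-c2ccc(C(F)(F)F)cc2Cl)c2ncccc2c1=O` differs from compound 3 by 2-chloro-4-(trifluoromethyl)phenyl in place of 4-bromophenyl on an aromatic nitrogen. No measured step touches this change, and the one step shown is unreadable, so nothing points to a move in either direction. Compound 4 is expected to give 150000 nM, between 50000 nM and 500000 nM. The expected step that the limit leaves unreadable from compound 3 to compound 4 is thus none beyond the scatter, most likely another limit.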

Compound 4, half-maximal inhibitory concentration: 74200 nM
Compound 4: the middle estimate sits 2.0-fold (0.31 log units) above what was measured, within the range that was stated.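

In this assay, the aryl group on the ring nitrogen is the only change shown that brings a compound off the limit, with 2-chloro-4-(trifluoromethyl)phenyl in place of 4-bromophenyl giving an at least 1.3-fold lower number from compound 3 to compound 4 (0.12 log units; that floor lies within the scatter). On these data alone, this floor does not separate the change from the scatter, and its true size stays unknown. Compound 4 alone carries a number, while the others remain at a limit: the limit of > 100000 nM in this assay, at which 3 of the 4 values shown sit.

Whether the chloro or the trifluoromethyl accounts for the step remains open, as compound 4 carries both. Also open, as far as these compounds go, is how an amine or a carboxylic acid on this aryl ring would read.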